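Loss of a Methoxy Group and Acid Dissociation

The source may hold more compounds than are shown below. What is called first, only, known or untested is meant among the compounds shown, and "the series" means these compounds.

Compound 1 `COc1cnc(C[S+]([O-])c2nc3cc(OCC(F)(F)F)ccc3[nH]2)c(C)c1OC` was examined in a physicochemical assay for acid dissociation, where compound 1 gives 8.61. Compound 2 `COc1ccnc(C[S+]([O-])c2nc3cc(OCC(F)(F)F)ccc3[nH]2)c1C` shares the core of compound 1 and differs from it in a single place: hydrogen in place of methoxy on an aromatic carbon. In this assay compound 2 gives 8.51, which works out to a number 0.10 log units lower from compound 1 to compound 2 (within the scatter). Compound 3 `COc1ccnc(C[S+]([O-])c2nc3cc(OC(F)(F)C(F)F)ccc3[nH]2)c1OC` rests on a different core; how the core of compound 3 differs from the core of compound 1 is not broken down here. In this assay compound 3 gives 8.08, the lowest of the three numbers, with compound 2 the nearest and compound 1 the furthest, both gaps beyond the scatter. Compound 4 `COc1ccnc(C[S+]([O-])c2nc3cc(OC(F)(F)C(F)F)ccc3[nH]2)c1` has not yet been measured. It differs from compound 3 in one place: hydrogen in place of methoxy on an aromatic carbon. This is the same kind of change as that from compound 1 to compound 2, but the surroundings differ: in compound 1 the carbon that loses its methoxy group is meta to a methyl group and para to a large group, whereas in compound 3 it is ortho to a large group. Because the earlier step of a number 0.10 log units lower from compound 1 to compound 2 (within the scatter) was small, the step from compound 3 to compound 4 is expected to be of similar size, a number 0.10 log units lower from compound 3 to compound 4 (within the scatter). Compound 4 is therefore estimated to give 7.98 in this assay, with a likely range from 7.6 to 8.4.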

Compound 4, acid dissociation constant: 7.91
The estimate for compound 4 lay 0.07 log units above the measured number; low and high end bracket the measured number.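

On the core of compound 3, hydrogen in place of methoxy on an aromatic carbon gives, in this assay, a number 0.17 log units lower from compound 3 to compound 4 (within the scatter) and on the core of compound 1 the same change gives a number 0.10 log units lower from compound 1 to compound 2 (within the scatter) so on both cores shown the step stays inside the usual scatter of repeated measurements, even though the surroundings of the carbon differ. This shows that, for these two pairs, carrying the change from one core to the other did not produce a step beyond the scatter, but it does not show that the change has a real effect on this read-out, that the two steps differ in size, or that the same would hold on any further core. Nothing given here bears on why the steps are this size.

The compounds shown leave open what an amine, a chlorine atom or a longer chain such as butoxy would give in this assay on this aromatic carbon, since only methoxy and hydrogen appear there. They also leave open whether the change stays this small on a core that carries neither the methyl group of compound 1 nor the large group ortho to the carbon in compound 3.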